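This account rests on a few compounds, and the source may have more. Where it says the series, first, only, none or still open, it means among the compounds named here.

Of the compounds shown here, three built on one shared core have so far been tested in an assay on cells (Hepatocyte, strain Sprague-Dawley) for inhibition of acyl-CoA desaturase 1 (Rattus norvegicus), read by HPLC; on this read-out lower numbers stand for stronger inhibition and higher numbers for weaker inhibition. Compound 1 `O=C(O)c1cncc(-c2ccc(N3CCC(Oc4ccccc4Cl)CC3)nn2)c1` gives 1890 nM in this assay. Compound 2 `O=C(O)c1cncc(-c2ccc(N3CCC(Oc4cc(F)c(F)cc4Br)CC3)nn2)c1` gives 563 nM, and compound 3 `O=C(O)c1cncc(-c2ccc(N3CCC(Oc4cc(F)ccc4Br)CC3)nn2)c1` gives 175 nM. Compound 3 therefore stands as the strongest inhibitor of the three, its steps to both others lying beyond the scatter: a 3.4-fold lower number from compound 1 to compound 2 (0.53 log units; beyond the scatter), an 11-fold lower number from compound 1 to compound 3 (1.03 log units; beyond the scatter) and a 3.2-fold lower number from compound 2 to compound 3 (0.51 log units; beyond the scatter). All three measured steps concern only the substituted phenyl on the ether oxygen.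

Compound 4 `O=C(O)c1ccc(-c2ccc(N3CCC(Oc4cc(F)ccc4Br)CC3)nn2)nc1` keeps that phenyl unchanged and instead rearranges the acid-bearing ring: 5-carboxypyridin-2-yl in place of 5-carboxypyridin-3-yl on an aromatic carbon. Among the measured compounds shown here, none of the measured steps touches this part of the molecule, so they offer no direct guide to the direction or size of the coming step. The acid is re-positioned relative to the rest of the core. A step of some size in either direction seems plausible, and the expectation is set cautiously near the current number with a wide range. The step from compound 3 is expected to be a 2.0-fold higher number from compound 3 to compound 4 (0.30 log units; within the scatter). Compound 4 is estimated at 350 nM, between 80 nM and 1600 nM.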

Compound 4, half-maximal inhibitory concentration: 159 nM
The estimate for compound 4 lay 2.2-fold (0.34 log units) above the measured number, and the stated range covers the measured number.
By their numbers in this assay, from the lowest: compounds 4 and 3 (each within the scatter of the next); then compound 2; then compound 1.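

In this assay, exchanging 5-carboxypyridin-3-yl for 5-carboxypyridin-2-yl gives a 1.1-fold lower number from compound 3 to compound 4 (0.04 log units; within the scatter), so the two compounds cannot be told apart on this read-out. The earlier steps shown here all changed the substituted phenyl on the ether oxygen, whereas this one shows that the same atoms of the acid-bearing ring, joined differently on the aromatic carbon of the ring with 2 nitrogen, can leave the number in place while the phenyl stays 2-bromo-5-fluorophenyl. No measurement available here explains why these two arrangements read alike. Still open, as far as these compounds go, is whether a primary amide or a tetrazole in place of the carboxylic acid would give a similar number. Also open, from the compounds shown here alone, is whether 2-chlorophenyl on the 5-carboxypyridin-2-yl compound would repeat the step seen among the first compounds.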